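Flipping One Stereocentre in Compound 2

This account rests on a few compounds, and the source may have more. Where it says the series, first, only, none or still open, it means among the compounds named here.

Of the compounds shown here, three built on a shared core have been measured in a functional assay on RAW264.7 cells (Mus musculus) for inhibition, with a stated time of 30 min; a lower number here means a stronger inhibitor, a higher number a weaker inhibitor. Compound 1 `C=C1C(=O)OC[C@H]1CCOC(=O)Nc1ccc(Br)cc1` gives 350 nM, compound 2 `C=C1C(=O)OC[C@@H]1CCOC(=O)Nc1ccc(C)c(C)c1` gives 1450 nM, and compound 3 `C=C1C(=O)OC[C@@H]1CCOC(=O)Nc1c(C)cccc1C(C)C` gives 5980 nM. Compound 2 therefore stands in the middle of the three, a weaker inhibitor than compound 1 and a stronger one than compound 3, with both gaps beyond the usual scatter.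

The next compound to consider is compound 4 `C=C1C(=O)OC[C@H]1CCOC(=O)Nc1ccc(C)c(C)c1`. Its difference from compound 2 is the two compounds have the same atoms and bonds and differ only in configuration as drawn: 1 of 1 stereo elements differ; a stereocentre at a saturated ring carbon is drawn R in compound 2 and S in compound 4. Nothing else changes, so this comparison tests the spatial arrangement alone.

Within the data shown here, no measured pair shows this change in isolation, so any forecast is tentative. Among the measured compounds shown here, the configuration drawn in compound 4 is shared by compound 1, and compound 1 gives 350 nM, the lowest number so far, but its ring substituent also differs from that of compound 2, so this is only a weak hint. A modest move towards a lower number in this assay is therefore expected, and a result within the scatter would be no surprise. The estimated change is a 1.6-fold lower number from compound 2 to compound 4 (0.21 log units; within the scatter). The expected value for compound 4 is 900 nM, within an estimated range of 300 nM to 2800 nM.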

Compound 4, half-maximal inhibitory concentration: 1090 nM
The estimate for compound 4 lay 1.2-fold (0.08 log units) below the measured number; measured number inside the range.
By their numbers in this assay, from the lowest: compound 1; then compounds 4 and 2 (each within the scatter of the next); then compound 3.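

Among these compounds, this is the first pair that tests the configuration at the saturated ring carbon on its own, and only one kind of difference is in play: the fact that compounds 2 and 4 differ only in the configuration as drawn. In this assay, the result is a 1.3-fold lower number from compound 2 to compound 4 (0.12 log units; within the scatter), so with this substitution pattern, the R and S forms as drawn cannot be told apart. Compound 1 at 350 nM shares its drawn configuration with compound 4 at 1090 nM, so that configuration alone does not produce the lower number of compound 1.

It remains open whether configuration matters as little when the rest of the molecule is different, as in compound 1 with its bromine or compound 3 with its bulkier isopropyl group, since neither has a partner of opposite configuration among the compounds shown. It is also unknown how a methoxy group or a carboxylic acid in place of the bromine of compound 1 would read in this assay, or whether either would make the two configurations easier to separate.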